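Benzyl to 2-hydroxyphenyl on the amide nitrogen

This account rests on a few compounds, and the source may have more. Where it says the series, first, only, none or still open, it means among the compounds named here.

Measured in a functional assay on MDA-MB-231 cells (Homo sapiens) for inhibition, read by MTT assay; a higher number here means a weaker inhibitor of growth, a lower number a stronger inhibitor of growth:
- Compound 1 `CC1=C(/C=C/C(C)=C/C=C/C(C)=C\C(=O)Nc2ccc(O)cc2)C(C)(C)CCC1n1ccnc1`: 13100 nM
- Compound 2 `CC1=C(/C=C/C(C)=C/C=C/C(C)=C\C(=O)Nc2cccc(F)c2)C(C)(C)CCC1n1ccnc1`: 8510 nM
- Compound 3 `CC1=C(/C=C/C(C)=C/C=C/C(C)=C\C(=O)NCc2ccccc2)C(C)(C)CCC1n1ccnc1`: 5880 nM

Compound 3 stands at the low end of these numbers, with a 2.2-fold lower number from compound 1 to compound 3 (0.35 log units; beyond the scatter) and only a 1.4-fold lower number from compound 2 to compound 3 (0.16 log units; within the scatter). Compound 4 `CC1=C(/C=C/C(C)=C/C=C/C(C)=C\C(=O)Nc2ccccc2O)C(C)(C)CCC1n1ccnc1` carries 2-hydroxyphenyl in place of benzyl on an amide-type nitrogen. The closest measured change is 4-hydroxyphenyl to benzyl, a 2.2-fold lower number from compound 1 to compound 3 (0.35 log units; beyond the scatter), and the change now runs the opposite way, from benzyl to a hydroxyphenyl group. The swap between aryl groups, a 1.5-fold lower number from compound 1 to compound 2 (0.19 log units; within the scatter), stayed small. A modest move toward a higher number is therefore expected. The expected step for compound 4 is a 1.9-fold higher number from compound 3 to compound 4 (0.27 log units; within the scatter). The estimate for compound 4 is 11000 nM, with an expected range of 5500 nM to 22000 nM.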

Compound 4, concentration for 50% growth inhibition: 4670 nM
Beside the measured number, compound 4's estimate is 2.4-fold (0.37 log units) above it; the measured number lies below the stated range.
By their numbers in this assay, from the lowest: compounds 4, 3, 2 and 1 (each within the scatter of the next, the first and the last beyond it).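

In this assay, 2-hydroxyphenyl on the amide-type nitrogen cannot be told apart from benzyl, a 1.3-fold lower number from compound 3 to compound 4 (0.10 log units; within the scatter), or from 3-fluorophenyl, a 1.8-fold lower number from compound 2 to compound 4 (0.26 log units; within the scatter), so a hydroxyphenyl group at this position does not by itself raise the number. The two hydroxyphenyl groups do differ, a 2.8-fold lower number from compound 1 to compound 4 (0.45 log units; beyond the scatter), which makes the place of the hydroxyl on the ring matter in this pair. Nothing available explains that difference.

Still open, as far as these compounds go, is whether an amine, a carboxylic acid or a longer chain in place of benzyl on the amide-type nitrogen would move the number beyond the scatter of compound 4.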